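The source may report more compounds than this note shows. Statements on the series, on what has been measured and on what is new or still open speak of the compounds shown alone.

Of the compounds shown here, three have been tested in a functional assay on RKO cells (Homo sapiens) for inhibition, read by MTT assay, with a stated time of 48 h; on this read-out lower numbers stand for stronger inhibition and higher numbers for weaker inhibition. Compound 1 `COc1ccc(N(C)c2nc(C)nc3ccccc23)cc1C(=O)OCCC[Se]C#N` gives 1140 nM, compound 3 `CN(c1ccc([Se]C#N)cc1)c1nc(C2CC2)nc2ccccc12` gives 51 nM, and compound 2 `C[Se]c1ccc(N(C)c2nc(C)nc3ccccc23)cc1C` gives 8 nM, the lowest of the three numbers; its gaps to compound 3 and to compound 1 both lie beyond the usual scatter, so compound 2 is the most potent of the measured set. The untested compound 4 `C[Se]c1ccc(N(C)c2nc(C)nc3ccccc23)cc1Cl` differs from compound 2 in one place: chloro in place of methyl on an aromatic carbon. Going by the values given here, no measured pair shows this exact change, so nothing here anchors its size. The expected step of a 1.5-fold higher number from compound 2 to compound 4 (0.18 log units; within the scatter) in this assay is small, within the scatter, with no firm direction. Compound 4 is therefore estimated at 12 nM, with a range from 4 nM to 40 nM.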

Compound 4, half-maximal inhibitory concentration: 4 nM
Estimate against measurement, compound 4: 3.0-fold (0.48 log units) above; measured number inside the range.
By their numbers in this assay, from the lowest: compounds 4 and 2 (each within the scatter of the next); then compound 3; then compound 1.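

In this assay, chloro in place of methyl on this aromatic carbon, ortho to a group of 2 heavy atoms and meta to a large group, gives a 2.0-fold lower number from compound 2 to compound 4 (0.30 log units; within the scatter). Going by these compounds alone, this is the first single-place comparison in the set, and it shows that the read-out does not separate these two groups at this position. No available evidence accounts for this result.

What other groups do here remains open: a plain hydrogen, an amine or a carboxylic acid at this carbon is not among the compounds shown. Going by these compounds, whether the same change reads alike on a different core also remains open.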